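Phenyl for Fluoro on the Pyridine of a Bicyclic Amine

The compounds below may be only part of what the source reports. "The series", "measured", "known", "first", "only" and "open" are said of these compounds alone.

Measured so far:
compound 1 `Clc1ccc(C2=CC3CNCC(C2)C3)cn1`: 141%
compound 2 `Fc1ccc(C2=CC3CNCC(C2)C3)cn1`: 140%

In an in vitro functional assay on SH-SY5Y cells for agonist activity at Neuronal acetylcholine receptor; alpha3/beta4 (Homo sapiens), read by FLIPR and calcium flux (on this read-out higher numbers stand for larger maximal responses and lower numbers for smaller maximal responses), compound 1 gives 141% and compound 2 gives 140%. The step of a number 1 percentage points lower from compound 1 to compound 2 (within the scatter) lies within the scatter, so compound 2 stands level with compound 1 on the numbers shown.

Compound 3 `C1=C(c2ccc(-c3ccccc3)nc2)CC2CNCC1C2` has not yet been measured in this assay. It differs from compound 2 by phenyl in place of fluoro on an aromatic carbon. Among the measured compounds shown here, the only measured step exchanges one halogen for another and says nothing about a phenyl entering at this place, so no measured step bears directly on this change, and a step in either direction cannot be ruled out. Compound 3 is therefore estimated at 115% with a range from 55% to 165%. The step of a number 25 percentage points lower from compound 2 to compound 3 (beyond the scatter) is expected to be modest, with wide uncertainty.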

Compound 3, largest response reached (reported as percent of maximum), in percent of the reference or control that the assay uses: 17%
Compound 3: middle estimate off by 98 percentage points, on the high side; the whole stated range lies above it.
By their numbers in this assay, from the lowest: compound 3; then compounds 2 and 1 (each within the scatter of the next).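

Fluoro and chloro stand level at this place, which showed only that one halogen can replace another. Phenyl on the aromatic carbon next to the ring nitrogen behaves differently: its entry brings a number 123 percentage points lower from compound 2 to compound 3 (beyond the scatter) and, against chloro, a number 124 percentage points lower from compound 1 to compound 3 (beyond the scatter) in the maximal response. The position therefore does not keep its response with every group, and a six-membered aromatic ring of carbon removes most of it.

As far as these compounds go, whether methyl, methoxy or an amine at this place would keep the response stays open. No data on hand say why phenyl lowers it.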